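A Fluorophenylsulfanyl Analogue of Compound 1 on EKVX Cells

A few compounds are considered here, and "the series" means these few. Any claim that something is new, unique, unknown or untested is made for them only; others in the source may bear on it.

Measured so far:
Compound 1 `Nc1cc(N)c2nc(-c3ccccc3)c(Oc3ccc(Cl)c(Cl)c3)nc2c1`: 2140 nM
Compound 2 `CCOC(=O)[C@H](CCC(=O)O)NC(=O)c1ccc(Sc2nc3cc(N)cc(N)c3nc2-c2ccccc2)cc1`: 18600 nM

In a functional assay on EKVX cells (Homo sapiens) for inhibition, read by sulforhodamine B assay, with a stated time of 48 h (on this read-out higher numbers stand for weaker inhibition of growth and lower numbers for stronger inhibition of growth), compound 1 gives 2140 nM, the lowest of the two numbers seen. Compound 2 gives 18600 nM in this assay, a gap beyond the usual scatter of repeated measurements. Compound 2 differs from compound 1 in more than one place, so these two values can only be compared as they stand and do not isolate any single change.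

Compound 3 `Nc1cc(N)c2nc(-c3ccccc3)c(Sc3ccc(F)cc3)nc2c1` has not yet been measured. It differs from compound 1 by (4-fluorophenyl)sulfanyl in place of 3,4-dichlorophenoxy on an aromatic carbon. Among the measured compounds shown here, no pair of measured compounds differs in one place, so no measured step guides the size of this change. The expected outcome is a small step toward weaker growth inhibition, a 1.6-fold higher number from compound 1 to compound 3 (0.21 log units; within the scatter), one that may well sit within the scatter. Compound 3 is therefore estimated to give 3500 nM in this assay, with a range from 1200 nM to 10000 nM.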

Compound 3, concentration for 50% growth inhibition: 20400 nM
Estimate against measurement, compound 3: 5.8-fold (0.77 log units) below; measured number outside the range, above it.
By their numbers in this assay, from the lowest: compound 1; then compounds 2 and 3 (each within the scatter of the next).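

Putting (4-fluorophenyl)sulfanyl in place of 3,4-dichlorophenoxy on the shared core gives a 9.5-fold higher number from compound 1 to compound 3 (0.98 log units; beyond the scatter) in this assay, so growth inhibition clearly depends on what is attached at this aromatic carbon, even though both groups carry a single carbon-only aromatic ring. The swap changes two things at once, with an oxygen link becoming a sulfur link and two chlorines giving way to one fluorine, so the step cannot be credited to either change alone. Nothing available here explains the size of this step.

Still open, going by these compounds, is whether a sulfur link carrying the 3,4-dichlorophenyl ring, or an oxygen link carrying the 4-fluorophenyl ring, would read closer to compound 1 or to compound 3. Also open, on these data alone, is how a morpholine ring or a longer alkyl chain would read at this position.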